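The source may report more compounds than this note shows. Statements on the series, on what has been measured and on what is new or still open speak of the compounds shown alone.

Within the data shown here, in an in vivo ADME assay on the whole organism (strain 129/SvEvBrd x C57BL/6) for pharmacokinetics, with Mus musculus as the target (on this read-out higher numbers stand for higher oral bioavailability and lower numbers for lower oral bioavailability), compound 1 `CN(C)C(=O)c1nc([C@@H](O)[C@H](O)[C@H](O)CO)c[nH]1` gives 5%, while compound 2 `Cc1nc(-c2nc([C@@H](O)[C@H](O)[C@H](O)CO)c[nH]2)cs1` gives 23%, the higher of the two numbers measured so far. Compound 3 `OC[C@@H](O)[C@@H](O)[C@H](O)c1c[nH]c(-c2cscn2)n1` has hydrogen in place of methyl on an aromatic carbon, so that 2-methyl-1,3-thiazol-4-yl becomes 1,3-thiazol-4-yl: hydrogen in place of methyl on an aromatic carbon. Among the measured compounds shown here, only one measured step bears on this change, and only loosely. That step, a number 18 percentage points higher from compound 1 to compound 2 (beyond the scatter), exchanged dimethylcarbamoyl for the whole 2-methyl-1,3-thiazol-4-yl group, so it cannot show what the methyl alone contributes. Since the new change is far smaller, no shift beyond the scatter is expected in this assay, with at most a slight drop. The estimated step is a number 3 percentage points lower from compound 2 to compound 3 (within the scatter). For compound 3 the expected value is 20%, with an estimated range from 8% to 36%.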

Compound 3, oral bioavailability: 12%
Compound 3: middle estimate off by 8 percentage points, on the high side; the measured number falls inside the stated range.
By their numbers in this assay, from the lowest: compounds 1 and 3 (each within the scatter of the next); then compound 2.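

In this assay, the methyl alone accounts for a step beyond the scatter, a number 11 percentage points lower from compound 2 to compound 3 (beyond the scatter), so the gain that the earlier step could credit only to the whole 2-methyl-1,3-thiazol-4-yl group depends in part on this one carbon substituent, next to the ring nitrogen and next to the ring sulfur. Without the methyl, the ring no longer separates itself from dimethylcarbamoyl, with the comparison reading a number 7 percentage points higher from compound 1 to compound 3 (within the scatter). Nothing available explains why the methyl matters here.

The compounds shown leave open whether an ethyl, an amine or a methoxy group on this same ring carbon would match or exceed methyl. They also leave open whether methyl would have a similar effect on a ring other than this thiazole.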